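The source may report more compounds than this note shows. Statements on the series, on what has been measured and on what is new or still open speak of the compounds shown alone.

Measured compounds:
compound 1 `O=C(Nc1cccc(-n2cc(-c3ccncc3)c(-c3ccc(Cl)c(O)c3)n2)c1)Nc1cccc(C(F)(F)F)c1` with 1810 nM
compound 2 `COc1cc(-c2nn(-c3cccc(NC(=O)Nc4cc(C(F)(F)F)cc(C(F)(F)F)c4)c3)cc2-c2ccncc2)ccc1Cl` with 892 nM
compound 3 `COc1cc(-c2nn(-c3cccc(NC(=O)c4cccc(C(F)(F)F)c4)c3)cc2-c2ccncc2)ccc1Cl` with 1990 nM

These three compounds were tested in a functional assay on Malme-3M cells (Homo sapiens) for inhibition, read by sulforhodamine B assay, with a stated time of 48 h; on this read-out higher numbers stand for weaker inhibition of growth and lower numbers for stronger inhibition of growth. Among them compound 3 stands at the highest number, with compound 1 closest to it at a separation that lies inside the usual scatter of this assay, so the two cannot be ranked against each other. Compound 2 sits further away, at a lower number that lies beyond the scatter, and so shows the stronger growth inhibition of the two.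

Compound 4 `COc1cc(-c2nn(-c3cccc(NC(=O)Nc4ccc(Cl)c(Cl)c4)c3)cc2-c2ccncc2)ccc1Cl` has not yet been measured. It differs from compound 3 in one place: (3,4-dichlorophenyl)amino in place of 3-(trifluoromethyl)phenyl on a carbonyl carbon. Within the data shown here, the core of compound 3 is shared by compound 2, which likewise carries a carbamoyl group; in this assay compound 2 gives 892 nM, which is the only guide to where a carbamoyl-bearing analogue may land. On that basis the step from compound 3 to compound 4 is expected to be a modest move toward a lower number, about a 2.0-fold lower number from compound 3 to compound 4 (0.30 log units; within the scatter). For compound 4 the value is estimated at 1000 nM, with a range from 400 nM to 2500 nM.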

Compound 4, concentration for 50% growth inhibition: 926 nM
Estimate against measurement, compound 4: 1.1-fold (0.03 log units) above; the measured number falls inside the stated range.
By their numbers in this assay, from the lowest: compounds 2, 4, 1 and 3 (each within the scatter of the next, the first and the last beyond it).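

Among these compounds, compound 3 and compound 4 give the first single-place comparison in this set: on a carbonyl carbon whose other neighbour is an amide-type nitrogen, replacing 3-(trifluoromethyl)phenyl with (3,4-dichlorophenyl)amino gives, in this assay, a 2.1-fold lower number from compound 3 to compound 4 (0.33 log units; beyond the scatter). The position therefore tolerates this exchange of one aromatic carbon ring for another joined through a nitrogen, and growth inhibition is modestly stronger after the change. Nothing available here explains the shift.

The change alters the link to the carbonyl carbon and the ring substituents together, so the compounds shown do not separate the contribution of the entering nitrogen from that of the two chlorines. On these data alone, whether the step depends on an aromatic ring at all also stays open, a question that a cyclohexylamino group at this position would address.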